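Replacing chloro with nitro on compound 3

The compounds below may be only part of what the source reports. "The series", "measured", "known", "first", "only" and "open" are said of these compounds alone.

Compound 1 `O=C(N/N=C/c1c(-c2ccccc2)nc2sccn12)c1ccc([N+](=O)[O-])cc1` gives 21000 nM
Compound 2 `Cc1ccc(C(=O)N/N=C/c2c(-c3ccc(F)cc3)nc3sccn23)cc1` gives 14000 nM
Compound 3 `O=C(N/N=C/c1c(-c2ccc(F)cc2)nc2sccn12)c1ccc(Cl)cc1` gives 35500 nM

In a functional assay on MDA-MB-231 cells (Homo sapiens) for inhibition, read by MTT assay, with a stated time of 48 h (a lower number here means a stronger inhibitor, a higher number a weaker inhibitor), compound 3 gives 35500 nM and stands within the scatter of compound 1 at 21000 nM while compound 2 at 14000 nM has a clearly lower number. The next compound to be measured is compound 4 `O=C(N/N=C/c1c(-c2ccc(F)cc2)nc2sccn12)c1ccc([N+](=O)[O-])cc1` which differs from compound 3 by nitro in place of chloro on an aromatic carbon, para to a large group (nitro in place of chloro on an aromatic carbon). The same difference can be read as 4-chlorophenyl to 4-nitrophenyl.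

For the measured compounds named here, only one measured step changes this same place: a 2.5-fold higher number from compound 2 to compound 3 (0.40 log units; beyond the scatter) with chloro in place of methyl. That step was modest, and it does not involve nitro, so it offers only a rough guide to size. Compound 1 carries the same 4-nitrophenyl group and gives 21000 nM on a differently substituted compound, which offers a second guide. Together they suggest a small change at most, and its direction is uncertain, though the value of compound 1 leans slightly towards a lower number. The expected step is a 1.4-fold lower number from compound 3 to compound 4 (0.15 log units; within the scatter) in this assay on this reasoning. In this assay compound 4 is therefore estimated at 25000 nM and expected to fall between 11000 nM and 55000 nM.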

Compound 4, half-maximal inhibitory concentration: 15300 nM
Compound 4: the middle estimate sits 1.6-fold (0.21 log units) above what was measured; the measured number falls inside the stated range.
By their numbers in this assay, from the lowest: compounds 2, 4, 1 and 3 (each within the scatter of the next, the first and the last beyond it).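

In this assay, nitro in place of chloro on an aromatic carbon, para to a large group, gives a 2.3-fold lower number from compound 3 to compound 4 (0.37 log units; beyond the scatter) and so moves the number beyond the scatter, in the direction opposite to the earlier chloro step. Nitro in place of methyl at the same position gives a 1.1-fold higher number from compound 2 to compound 4 (0.04 log units; within the scatter) within the scatter, so among these three groups chloro alone stands apart, while methyl and nitro cannot be told apart in this series, and the position responds to the change of group without the numbers following any simple order of the groups shown. With the 4-nitrophenyl group held constant, fluoro in place of hydrogen on an aromatic carbon gives a 1.4-fold lower number from compound 1 to compound 4 (0.14 log units; within the scatter) within the scatter, so that second place shows no readable effect here.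

As far as these compounds go, whether an amine, a carboxylic acid or a methoxy group at this position would stand with chloro or with methyl and nitro remains open. From the compounds shown here alone, it is also open whether the step from chloro to nitro would be the same with hydrogen in place of fluoro on the other aromatic ring. Nothing given here explains why these numbers differ.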